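Growth of the substituent on the saturated chain carbon bound to an aromatic nitrogen

The compounds below may be only part of what the source reports. "The series", "measured", "known", "first", "only" and "open" are said of these compounds alone.

Compound 1 `Cn1nc(-c2cccnc2)c2ccccc2c1=O` is the parent with hydrogen on the saturated chain carbon bound to an aromatic nitrogen. In an assay on isolated protein (Oryctolagus cuniculus) with Thromboxane-A synthase (Homo sapiens) as the target, tested at 1 uM (a higher number here means more inhibition at the concentration tested (going by the name of the read-out), a lower number less inhibition), compound 1 gives 63%, the lowest of the three numbers measured. Compound 2 `CCCCCCCCn1nc(-c2cccnc2)c2ccccc2c1=O` gives 99% and compound 3 `O=c1c2ccccc2c(-c2cccnc2)nn1CCSc1nccs1` gives 97%. The step of a number 36 percentage points higher from compound 1 to compound 2 (beyond the scatter) and the step of a number 34 percentage points higher from compound 1 to compound 3 (beyond the scatter) both bear on the change to compound 4 `CC(C)NC(=O)CCCn1nc(-c2cccnc2)c2ccccc2c1=O`, which carries 2-(isopropylcarbamoyl)ethyl in place of hydrogen on a saturated chain carbon bound to an aromatic nitrogen. Because the step of a number 36 percentage points higher from compound 1 to compound 2 (beyond the scatter) and the step of a number 34 percentage points higher from compound 1 to compound 3 (beyond the scatter) both rise beyond the scatter, a step of similar direction is expected for compound 4, namely a number 27 percentage points higher from compound 1 to compound 4 (beyond the scatter). Compound 4 is therefore estimated at 90%, with a range from 70% to 99%.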

Compound 4, a percentage reported as inhibition, at one concentration (the size of the read-out at that concentration, not a potency): 89%
The estimate for compound 4 lay 1 percentage points above the measured number; low and high end bracket the measured number.
By their numbers in this assay, from the lowest: compound 1; then compounds 4, 3 and 2 (each within the scatter of the next).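

In this assay, the 2-(isopropylcarbamoyl)ethyl group gives a number 26 percentage points higher from compound 1 to compound 4 (beyond the scatter), so a substituent carrying a hydrogen-bond donor and acceptor also rises beyond the scatter at this place. This amide chain does not separate from the two earlier substituents: the reading is a number 8 percentage points lower from compound 3 to compound 4 (within the scatter) and a number 10 percentage points lower from compound 2 to compound 4 (within the scatter). Nothing given here bears on the reason for these steps. Going by these compounds, it remains open whether an amine or a carboxylic acid in place of the isopropylcarbamoyl would give a similar number.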